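The source may hold more compounds than are shown below. What is called first, only, known or untested is meant among the compounds shown, and "the series" means these compounds.

Measured so far in a functional assay on A549 cells (Homo sapiens) for inhibition, read by sulforhodamine B assay, with a stated time of 72 h; on this read-out lower numbers stand for stronger inhibition and higher numbers for weaker inhibition:
- compound 1 `Nc1sc(-c2ccc(Cl)cc2)c(-c2ccc(Cl)cc2)c1C(=O)N1CCCCC1`: 4620 nM
- compound 2 `CCCCNC(=O)c1c(N)sc(-c2ccc(Cl)cc2)c1-c1ccc(Cl)cc1`: 8170 nM

Among the compounds with values here, with only two numbers available, compound 1 lies within the scatter of compound 2, so the pair cannot be ranked. The next compound, compound 3 `CC(=O)Nc1sc(-c2ccc(Cl)cc2)c(-c2ccc(Cl)cc2)c1C(=O)N1CCCCC1`, keeps the core and the carbonyl group of compound 1 and changes the amino group to acetamido: acetyl in place of hydrogen on a nitrogen on an aromatic ring. Within the data shown here, the one measured step is a 1.8-fold higher number from compound 1 to compound 2 (0.25 log units; within the scatter). Among the measured compounds shown here, it swaps piperidin-1-yl for butylamino on a carbonyl carbon, so it does not touch this nitrogen, and no measured pair tests a change there. The data therefore point to no direction, and no step beyond the scatter is expected in this assay, though with wide uncertainty. The expected change is a 1.3-fold higher number from compound 1 to compound 3 (0.11 log units; within the scatter). The estimate for compound 3 is 6000 nM, with an expected range of 1800 nM to 20000 nM.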

Compound 3, half-maximal inhibitory concentration: 6010 nM
For compound 3 the middle estimate is 1.0-fold (0.00 log units) below the measured one, within the range that was stated.
By their numbers in this assay, from the lowest: compounds 1, 3 and 2 (each within the scatter of the next).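

Within the data shown here, this is the first measured change on the nitrogen on the aromatic ring, a position the earlier pair left untouched. In this assay, acetyl in place of hydrogen gives a 1.3-fold higher number from compound 1 to compound 3 (0.11 log units; within the scatter), so compound 1 and compound 3 cannot be told apart. For this one pair, the nitrogen therefore accepts an acetyl group, with its three added heavy atoms, without a step beyond the scatter. No available evidence explains this result.

A single acyl group on a single core says little about the position in general, so a longer acyl chain, a benzoyl group or a methanesulfonyl group on this nitrogen might behave differently. From the compounds shown here alone, it also remains open whether acetamido would give a similar result with butylamino on the carbonyl carbon.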